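Three Analogues at the Limit and a Fourth Aryl Swap

This account rests on a few compounds, and the source may have more. Where it says the series, first, only, none or still open, it means among the compounds named here.

Compound 3 `N#CC1=C(N)Oc2c(N)cc3nc4ccccc4nc3c2C12C(=O)N(Cc1cnnn1-c1ccc(Cl)cc1)c1ccccc12` is one of three closely related compounds tested in a functional assay on HepG2 cells (Homo sapiens) for antiproliferative activity, read by MTT assay, with a stated time of 48 h; a higher number here means a weaker inhibitor, a lower number a stronger inhibitor. Compound 3 gives only a limit, > 50000 nM. Compound 1 `CCOc1ccccc1-n1nncc1CN1C(=O)C2(C(C#N)=C(N)Oc3c2c2nc4ccccc4nc2c2ccccc32)c2ccccc21` likewise gives only a limit, > 50000 nM. Compound 2 `Cc1ccc(Cl)cc1-n1nncc1CN1C(=O)C2(C(C#N)=C(N)Oc3c2c2nc4ccccc4nc2c2ccccc32)c2ccccc21` gives only a limit, > 50000 nM. Among the measured compounds shown here, the single measured step, a step that the two limits leave unreadable from compound 1 to compound 2, cannot be read because of the limit of > 50000 nM in this assay, at which 3 of the 3 values shown sit, so none of these values says how large the change between any two compounds really is.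

Compound 4 `Cc1ccc(-n2nncc2CN2C(=O)C3(C(C#N)=C(N)Oc4c(N)cc5nc6ccccc6nc5c43)c3ccccc32)cc1Cl` has not yet been measured. It differs from compound 3 in one place: 3-chloro-4-methylphenyl in place of 4-chlorophenyl on an aromatic nitrogen. For the measured compounds named here, the only measured step concerns a change of the same kind, a different group on that aromatic nitrogen, and its size is not readable. The step that the limit leaves unreadable from compound 3 to compound 4 is therefore expected to be small, with no direction beyond the scatter. Compound 4 is expected to give about 60000 nM, within 20000 nM to 200000 nM, and most likely to be reported again only as a limit.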

Compound 4, half-maximal inhibitory concentration: > 50000 nM
Compound 4: no number, only a limit (the forecaster's own chance of this, stated with the estimate: 85%); the middle value is on the limit's open side.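

Among the compounds shown here, compound 3 and compound 4 each give only a limit in this assay, so no step between them can be read: the limit of > 50000 nM in this assay, at which 4 of the 4 values shown sit. The compounds shown leave open what the true value of each compound is, and whether changing the group on that aromatic nitrogen makes any difference.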